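The source may hold more compounds than are shown below. What is called first, only, known or untested is meant among the compounds shown, and "the series" means these compounds.

Compound 1 `Nc1scc(CN2CCN(c3ccc(Cl)cc3F)CC2)c1C(=O)c1ccc(Cl)cc1`: -57%
Compound 2 `Nc1scc(CN2CCN(c3ccc(OC(F)(F)F)cc3)CC2)c1C(=O)c1ccc(Cl)cc1`: -51%
Compound 3 `Nc1scc(CN2CCN(c3cccc(F)c3)CC2)c1C(=O)c1ccc(Cl)cc1`: -86%

These three compounds share one core and differ only in the aryl group on the ring amine. In a functional assay on CHO cells with adenosine receptor A1 (Homo sapiens) as the target, read by cAMP accumulation and immunoassay, with a stated time of 6 min, tested at 1 uM (a higher number here means a weaker effect of the compound at the concentration tested, a lower number a stronger effect), compound 3 gives the lowest number of the three and so the strongest effect at the tested concentration: its nearest neighbour is compound 1, with a number 29 percentage points lower from compound 1 to compound 3 (beyond the scatter), and compound 2 lies further off, with a number 35 percentage points lower from compound 2 to compound 3 (beyond the scatter). Compound 4 `Nc1scc(CN2CCN(c3ccc(F)cc3F)CC2)c1C(=O)c1ccc(Cl)cc1` has not yet been measured. It differs from compound 3 by 2,4-difluorophenyl in place of 3-fluorophenyl on an amine nitrogen in a ring. Among the compounds with values here, the step that bears most on this is the one from compound 1 to compound 3, since the 4-chloro-2-fluorophenyl of compound 1 resembles the 2,4-difluorophenyl that enters; moving the other way, a modest rise in the number is expected for compound 4, a number 21 percentage points higher from compound 3 to compound 4 (beyond the scatter). Compound 4 is therefore estimated at -65%, between -85% and -45%.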

Compound 4, a percentage reported as activity, at one concentration (the size of the read-out at that concentration, not a potency): -66%
Compound 4: the middle estimate sits 1 percentage points above what was measured, and the stated range covers the measured number.
By their numbers in this assay, from the lowest: compound 3; then compounds 4, 1 and 2 (each within the scatter of the next, the first and the last beyond it).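

In this assay, fluoro in place of chloro on this aryl ring leaves the read-out within the scatter (a number 9 percentage points lower from compound 1 to compound 4 (within the scatter)). The 2,4-difluorophenyl group gives a weaker effect than 3-fluorophenyl (a number 20 percentage points higher from compound 3 to compound 4 (beyond the scatter)) but a stronger one than 4-(trifluoromethoxy)phenyl (a number 15 percentage points lower from compound 2 to compound 4 (beyond the scatter)). Nothing available explains these differences. The compounds shown leave open how 3-chlorophenyl or 3-methoxyphenyl would compare with 3-fluorophenyl on this ring nitrogen. They also leave open whether a pyridine ring could replace the phenyl ring.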